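A few compounds are considered here, and "the series" means these few. Any claim that something is new, unique, unknown or untested is made for them only; others in the source may bear on it.

Of the compounds shown here, two sharing one core have been tested so far in a physicochemical assay for solubility; on this read-out higher numbers stand for higher solubility and lower numbers for lower solubility. Compound 1 (`CCOc1ccc2c(c1)C=CN(C)C(=O)C2C`) gives >= 120 ug/mL, which is a limit of the assay and not an exact number. Compound 2 (`COCCOc1ccc2c(c1)C=CN(C)C(=O)[C@@H]2C`) gives >= 128 ug/mL, which is also a limit. With only these two limits available, no order between the compounds can be read, and compound 2 has no exact place on the scale.

Compound 3 (`C[C@H]1C(=O)N(C)C=Cc2cc(CCO)ccc21`) keeps the core of compound 2 but changes one group: 2-hydroxyethyl in place of 2-methoxyethoxy on an aromatic carbon. Here, 2-hydroxyethyl stands in place of 2-methoxyethoxy on an aromatic carbon. Going by the values given here, no pair of measured compounds shows a change of this kind, so there is no direct guide to the size of the step. The expectation is for no shift beyond the usual scatter, in either direction, and for another reading reported as a limit. It rests on compound 2, with its limit of >= 128 ug/mL. The expected change is an at least 1.0-fold lower number from compound 2 to compound 3 (0.01 log units; that floor lies within the scatter). In this assay, compound 3 is estimated at 125 ug/mL, within an expected range of 70 ug/mL to 220 ug/mL.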

Compound 3, solubility: >= 108 ug/mL
Compound 3: only a limit was reported (the forecaster's own chance of this, stated with the estimate: 65%); the middle value is on the limit's open side.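

Going by these compounds alone, compound 2 and compound 3 are both reported only as limits in this assay, so no step from one to the other can be read. The compounds shown leave open where the exact value of each lies, and whether 2-hydroxyethyl in place of 2-methoxyethoxy on an aromatic carbon shifts the read-out at all, or in which direction.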